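Swapping hydroxy for cyano on the aryl alkyne terminus

The source may report more compounds than this note shows. Statements on the series, on what has been measured and on what is new or still open speak of the compounds shown alone.

The measured compounds and their values in a functional assay on MDA-MB-435 cells (Homo sapiens) for cytotoxicity (a higher number here means a weaker inhibitor of growth, a lower number a stronger inhibitor of growth), are these: compound 1, `OCCCCC#Cc1ccccc1C#Cc1ccccn1`, gives 25100 nM; compound 2, `OCCCCC#Cc1ccccc1C#Cc1cccs1`, gives 16600 nM; compound 3, `OCCCCC#Cc1ccccc1C#Cc1ccc(O)cc1`, gives 16100 nM.

Compound 3 has the lowest of the three numbers in this assay, but its margin over the others is slight: the step of a 1.0-fold lower number from compound 2 to compound 3 (0.01 log units; within the scatter) and the step of a 1.6-fold lower number from compound 1 to compound 3 (0.19 log units; within the scatter) both fall within the scatter, so compound 3 cannot be called more potent than compound 1 or compound 2 on these data.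

Compound 4, `N#Cc1ccc(C#Cc2ccccc2C#CCCCCO)cc1`, is the next analogue. It differs from compound 3 by cyano in place of hydroxy on an aromatic carbon. Among the measured compounds shown here, the steps that bear on this change are the earlier exchanges at the same triple-bonded position: a 1.5-fold lower number from compound 1 to compound 2 (0.18 log units; within the scatter), a 1.6-fold lower number from compound 1 to compound 3 (0.19 log units; within the scatter) and a 1.0-fold lower number from compound 2 to compound 3 (0.01 log units; within the scatter). All three were within the scatter, whether the group on the alkyne was pyridin-2-yl, thiophen-2-yl or 4-hydroxyphenyl. None of these involved a cyano group, so the move from compound 3 to compound 4 rests on an analogy rather than on a direct precedent.

Compound 4 is therefore expected to show a step of about a 1.0-fold lower number from compound 3 to compound 4 (0.00 log units; within the scatter) in this assay, not beyond the scatter. The estimate for compound 4 is 16000 nM, with a range from 6000 nM to 45000 nM.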

Compound 4, concentration for 50% growth inhibition: 18900 nM
Estimate against measurement, compound 4: 1.2-fold (0.07 log units) below; low and high end bracket the measured number.
By their numbers in this assay, from the lowest: compounds 3, 2, 4 and 1 (each within the scatter of the next).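

In this assay, the exchange of hydroxy for cyano on an aromatic carbon, para to a large group, gives a 1.2-fold higher number from compound 3 to compound 4 (0.07 log units; within the scatter). The earlier steps shown here exchanged the whole group on the triple-bonded carbon, whereas this one keeps the six-membered aromatic ring and alters only what it carries, and it shows that losing the hydrogen-bond donor of the hydroxy at this place, with a nitrile taking its place, leaves the number within the scatter. No measurement shown here offers an explanation for this result.

Going by these compounds, the four compounds span only a narrow band in this assay, so it remains open whether any group at this place, such as an amine, a carboxylic acid or a methoxy group, would give a step beyond the scatter. The hydroxy-bearing chain on the other triple bond is also the same throughout, which leaves open what a shorter or longer chain, or an amine at its end, would do to the number.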